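Working notes: replacing the carbamoyl group of compound 3

This account rests on a few compounds, and the source may have more. Where it says the series, first, only, none or still open, it means among the compounds named here.

In a functional assay on OVCAR-5 cells (Homo sapiens) for inhibition, read by sulforhodamine B assay, with a stated time of 48 h (a higher number here means a weaker inhibitor of growth, a lower number a stronger inhibitor of growth), compound 1 `CCCCCCCCCCCC[C@@H](O)[C@H]1CC[C@H]([C@H](O)CCCCCCCCCCNC(=O)c2ccnn2C)O1` reads 100000 nM and compound 2 `CCCCCCCCCCCC[C@@H](O)[C@H]1CC[C@H]([C@H](O)CCCCCCCCCCN(C)C(=O)c2ccnn2C)O1` reads 14100 nM while compound 3 `CCCCCCCCCCCC[C@@H](O)[C@H]1CC[C@H]([C@H](O)CCCCCCCCCCC(=O)Nc2ccnn2C)O1` reads 100000 nM and so stands level with compound 1 at the highest number of the three. The change to compound 4 `CCCCCCCCCCCC[C@@H](O)[C@H]1CC[C@H]([C@H](O)CCCCCCCCCCOC(=O)c2ccnn2C)O1` is ((1-methyl-1H-pyrazol-5-yl)carbonyl)oxy in place of (1-methyl-1H-pyrazol-5-yl)carbamoyl on a saturated chain carbon, ten or more bonds along the chain from an oxygen on a saturated carbon and a saturated ring carbon and nothing else differs. Swapping the amide for the carbamoyl gave no change at the digits printed from compound 1 to compound 3 (within the scatter) and so offers no guide on its own. Going by the values given here, compound 2, the only measured member lacking the amide hydrogen, shows a 7.1-fold lower number from compound 1 to compound 2 (0.85 log units; beyond the scatter) and the return shows a 7.1-fold higher number from compound 2 to compound 3 (0.85 log units; beyond the scatter) as its mirror. Compound 4 also has no such hydrogen, so a lower number is expected in this assay on this single precedent. Among the compounds with values here, the expected step is a 3.3-fold lower number from compound 3 to compound 4 (0.52 log units; beyond the scatter) at a size no larger than that precedent. The estimate for compound 4 is 30000 nM with 8000 nM to 100000 nM as the expected range.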

Compound 4, concentration for 50% growth inhibition: 100000 nM
Estimate against measurement, compound 4: 3.3-fold (0.52 log units) below; the range from low to high includes it.
By their numbers in this assay, from the lowest: compound 2; then compounds 1, 3 and 4 (each within the scatter of the next).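

In this assay, the ((1-methyl-1H-pyrazol-5-yl)carbonyl)oxy group shows that lacking the amide hydrogen is not enough on its own, with no change at the digits printed from compound 3 to compound 4 (within the scatter) and no change at the digits printed from compound 1 to compound 4 (within the scatter). The methylated amide remains the only exception, with a 7.1-fold higher number from compound 2 to compound 4 (0.85 log units; beyond the scatter), and compound 4 goes against any rule covering all groups without that hydrogen. No supporting data bear on the reason for this result. From the compounds shown here alone, it remains open whether a methyl on the carbamoyl nitrogen of compound 3 would match compound 2, and whether an amine at this place would do the same.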